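The source may report more compounds than this note shows. Statements on the series, on what has been measured and on what is new or still open speak of the compounds shown alone.

Three compounds on a shared core were examined in a functional assay on A549 cells (Homo sapiens) for cytotoxicity, read by MTT assay, with a stated time of 48 h; on this read-out lower numbers stand for stronger inhibition and higher numbers for weaker inhibition. For compound 1 `CCCCNCCOc1c(O)cc(O)c2c(=O)cc(-c3ccccc3)oc12` the entry reads "not determined" (no result reported). Compound 3 `CN(C)CCCOc1c(O)cc(O)c2c(=O)cc(-c3ccccc3)oc12` gives > 100000 nM, which is a limit of the assay and not a number. Going by the values given here, compound 2 `COc1c(OCCCCN2CCCCC2)cc(O)c2c(=O)cc(-c3ccccc3)oc12` gives 1150 nM, the only actual number among the three. Compound 4 `COc1c(OCCCCN2CCN(C)CC2)cc(O)c2c(=O)cc(-c3ccccc3)oc12` has not yet been measured, and it departs from compound 2 in one place: 4-methylpiperazin-1-yl in place of piperidin-1-yl on a saturated chain carbon, four bonds along the chain from an oxygen on an aromatic ring. Among the compounds with values here, no measured pair shows this change, so the expectation is anchored on compound 2 at 1150 nM alone. In this assay a small move towards weaker inhibition is expected, namely a 2.2-fold higher number from compound 2 to compound 4 (0.34 log units; beyond the scatter). For compound 4 the expected value is 2500 nM, with an estimated range from 800 nM to 8000 nM.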

Compound 4, half-maximal inhibitory concentration: 1500 nM
The estimate for compound 4 lay 1.7-fold (0.22 log units) above the measured number, and the stated range covers the measured number.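

In this assay the measured step is a 1.3-fold higher number from compound 2 to compound 4 (0.12 log units; within the scatter) and so, at this place on the chain, 4-methylpiperazin-1-yl and piperidin-1-yl cannot be told apart. The earlier compounds offered no pair for this change, whereas here both ends are actual numbers and neither compound sits at the limit of the assay: the limit of > 100000 nM in this assay, at which 1 of the 4 values shown sits.

From the compounds shown here alone, whether a morpholin-4-yl group or a primary amine at the same place would read the same remains open. So does whether this match would hold on a longer chain.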